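The source may report more compounds than this note shows. Statements on the series, on what has been measured and on what is new or still open speak of the compounds shown alone.

Compound 1, `C/C(=C/CN)CN(C[C@H]1Cc2ccccc2CN1)[C@H]1CCCc2cccnc21`, gives 28 nM in a functional assay on CCRF-CEM cells for antagonist activity at C-X-C chemokine receptor type 4 (Homo sapiens), read by calcium flux, with stated times of 25 min and 90 s; a higher number here means a weaker inhibitor, a lower number a stronger inhibitor.
Compound 2, `N[C@H]1CC[C@H](N(C[C@H]2Cc3ccccc3CN2)[C@H]2CCCc3cccnc32)CC1`, gives 34 nM in this assay.
Compound 3, `NCC1CC1CN(C[C@H]1Cc2ccccc2CN1)[C@H]1CCCc2cccnc21`, gives 6.4 nM; 13 nM (2 entries) in this assay.

All three share one core and differ only in the group carried on the amine nitrogen. Compound 1 has the lowest of the two single numbers, though the gap to its neighbour is small: a 1.2-fold higher number from compound 1 to compound 2 (0.08 log units; within the scatter), so the two cannot be told apart. Compound 3 has two entries rather than one number (the several entries of compound 3 in this assay, 6.4 nM; 13 nM (2 entries)), and they show how far repeats of one compound can drift.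

Compound 4, `C/C(CN(C[C@H]1Cc2ccccc2CN1)[C@H]1CCCc2cccnc21)=C(/F)CN`, has not yet been measured. It differs from compound 1 in one place: a group of 6 heavy atoms (4 carbon, 1 nitrogen, 1 fluorine; no ring) in place of a group of 5 heavy atoms (4 carbon, 1 nitrogen; no ring), on a saturated chain carbon bound to an amine nitrogen. The change is modest: a fluorine-bearing version of a similar amine chain stands where the chain of compound 1 was. For the measured compounds named here, no measured step involves a fluorine on this chain; the only measured step, which swaps the whole chain for a ring, stays within the scatter, which suggests this part of the molecule accepts changes without a large shift. A change smaller than that swap is therefore expected to move the number little, if at all, and the expected step is a 1.1-fold higher number from compound 1 to compound 4 (0.03 log units; within the scatter). Compound 4 is estimated at 30 nM, with a range from 10 nM to 90 nM.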

Compound 4, half-maximal inhibitory concentration: 1800 nM
Beside the measured number, compound 4's estimate is 60-fold (1.78 log units) below it; the whole stated range lies below it.
By their numbers in this assay, from the lowest: compounds 1 and 2 (each within the scatter of the next); then compound 4.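

In this assay, for the compounds shown here, the chain on the amine nitrogen turns out to be far less forgiving than the earlier compounds suggested: bringing in the 3-amino-2-fluoro-1-methylprop-1-en-1-yl group gives a 64-fold higher number from compound 1 to compound 4 (1.81 log units; beyond the scatter), although the only change in atoms is one added fluorine. The earlier swap to a 4-aminocyclohexyl group stayed within the scatter, yet the new chain also stands well apart from that ring, with a 53-fold higher number from compound 2 to compound 4 (1.72 log units; beyond the scatter), so the number of atoms changed is a poor guide to the size of a step at this place. Nothing measured here explains the large loss.

As far as these compounds go, whether a chlorine or a methyl group on the same chain would behave like the fluorine remains open. So does whether a fluorine on the 4-aminocyclohexyl ring would cost as much.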